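Compound 1 to its 4-fluorobenzyl analogue, compound 4

A few compounds are considered here, and "the series" means these few. Any claim that something is new, unique, unknown or untested is made for them only; others in the source may bear on it.

Going by the values given here, in a functional assay on SK-OV-3 cells (Homo sapiens) for antiproliferative activity, read by MTT assay, with a stated time of 48 h (a lower number here means a stronger inhibitor, a higher number a weaker inhibitor), compound 1 `Cc1c(Cc2ccccc2)c(=O)oc2cc(OCCOc3no[n+]([O-])c3S(=O)(=O)c3ccccc3)ccc12` gives 17.3 nM, the lowest of the three numbers measured so far. Compound 2 `COc1cc(OCCOc2no[n+]([O-])c2S(=O)(=O)c2ccccc2)ccc1C(=O)/C=C/c1ccccc1` gives 35.8 nM, and compound 3 `COCCOc1no[n+]([O-])c1S(=O)(=O)c1ccccc1` gives 3910 nM. Compound 4 `Cc1c(Cc2ccc(F)cc2)c(=O)oc2cc(OCCOc3no[n+]([O-])c3S(=O)(=O)c3ccccc3)ccc12` is not yet measured. It differs from compound 1 in one place: fluoro in place of hydrogen on an aromatic carbon, para to a large group, so that benzyl becomes 4-fluorobenzyl. Among the compounds with values here, the series offers no measured one-place step to serve as a precedent. In this assay, no step beyond the scatter is expected, in either direction. For compound 4 the expected value is 16 nM, with an estimated range of 7 nM to 38 nM.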

Compound 4, half-maximal inhibitory concentration: 8.3 nM
For compound 4 the middle estimate is 1.9-fold (0.29 log units) above the measured one; measured number inside the range.
By their numbers in this assay, from the lowest: compound 4; then compound 1; then compound 2; then compound 3.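

Fluoro in place of hydrogen on an aromatic carbon, para to a large group, is the first one-place change that can be read in this assay, and it lowers the number (a 2.1-fold lower number from compound 1 to compound 4 (0.32 log units; beyond the scatter)). This carbon therefore accepts fluoro with a modest gain, and benzyl to 4-fluorobenzyl keeps the series at its low end. No measurement here bears on why the number falls.

As far as these compounds go, it remains open whether chloro, methoxy or an amine at the same carbon would move the number further. From the compounds shown here alone, it also remains open whether phenyl to 4-fluorophenyl would act the same way on compound 2.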